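The source may hold more compounds than are shown below. What is called first, only, known or untested is meant among the compounds shown, and "the series" means these compounds.

Measured so far:
compound 1 `COc1ccc(-c2cn(-c3ccc(OC)cc3)nn2)cc1` — > 100 nM
compound 2 `COc1ccc(-n2cc(-c3ccc(N)cc3)nn2)cc1` — > 100 nM
compound 3 `COc1ccc(-c2cn(-c3ccc(OC)c(OC)c3)nn2)cc1` — > 10000 nM

In a functional assay on MDA-MB-231 cells (Homo sapiens) for cytotoxicity, read by MTT assay (a higher number here means a weaker inhibitor, a lower number a stronger inhibitor), compound 1 returns only a limit, > 100 nM. Compound 2 likewise returns only a limit, > 100 nM. Compound 3 returns a limit too, > 10000 nM. The cores of compound 1 and compound 2 differ by amino in place of methoxy on an aromatic carbon, giving the step that the two limits leave unreadable from compound 1 to compound 2. The step that the two limits leave unreadable from compound 1 to compound 3 rests on (methoxy in place of hydrogen on an aromatic carbon). Both steps stay unreadable because the limit of > 100 nM in this assay, at which 2 of the 3 values shown sit, and the limit of > 10000 nM in this assay, at which 1 of the 3 values shown sits, cap the values. Compound 4 `COc1ccc(-n2cc(-c3ccc(N)cc3)nn2)c(OC)c1` is not yet measured; it carries the same kind of change, (methoxy in place of hydrogen on an aromatic carbon), though the surroundings differ: in compound 3 the entering methoxy is ortho to a methoxy group and meta to a large group, in compound 4 ortho to a large group and meta to a methoxy group. The step from compound 2 to compound 4 is expected as a step that the limit leaves unreadable from compound 2 to compound 4, set beside the earlier one, resting on the step that the two limits leave unreadable from compound 1 to compound 3. Compound 4 is estimated at 20000 nM, between 3000 nM and 100000 nM.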

Compound 4, half-maximal inhibitory concentration: > 10000 nM
Compound 4 gave a limit, no number (the forecaster's own chance of this, stated with the estimate: 70%); the middle value does not contradict the limit.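

Among these compounds, compound 2 and compound 4 both return only limits, so no step between them can be read. The compounds shown leave open whether methoxy in place of hydrogen changes cytotoxicity at all.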